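This account rests on a few compounds, and the source may have more. Where it says the series, first, only, none or still open, it means among the compounds named here.

Compound 1 `COc1ccc(-c2c(C)nn(-c3nc(-c4ccc(Cl)c(Cl)c4)c(SC(C)C)s3)c2C(=O)O)cc1` and compound 2 `CCOc1ncccc1-c1c(C)nn(-c2nc(-c3ccc(Cl)c(Cl)c3)c(SC(C)C)s2)c1C(=O)O` share one core and differ only in the aromatic group that sits beside the carboxylic acid. In a functional assay on BJAB cells (Homo sapiens) for antiproliferative activity, with a stated time of 4 days (on this read-out higher numbers stand for an effect only at larger amounts of compound and lower numbers for an effect already at smaller amounts), compound 1 gives 2100 nM, and in the same test compound 2 gives 11000 nM. Compound 3 `Cc1c(-c2cc(Cl)cc(Cl)c2)c(C(=O)O)nn1-c1nc(-c2cnn(C)c2)c(SC(C)C)s1`, which carries a different pattern of groups, was reported in this assay as "not active" (no number reported), without a number. Among the two numbers available compound 2 therefore stands at the higher end, and the one step measured at this position, a 5.2-fold higher number from compound 1 to compound 2 (0.72 log units; beyond the scatter), was of modest size. Compound 4 `Cc1nn(-c2nc(-c3ccc(Cl)c(Cl)c3)c(SC(C)C)s2)c(C(=O)O)c1-c1ccccc1[N+](=O)[O-]` keeps the core of compound 2 and changes that same position: 2-nitrophenyl in place of 2-ethoxypyridin-3-yl on an aromatic carbon. Among the compounds with values here, the only step that bears on this change is the swap from compound 1 to compound 2, so the direction for a new aromatic group at this place is open, and a shift of roughly that size in either direction would not be surprising. Compound 4 is expected to show a step of a 2.2-fold lower number from compound 2 to compound 4 (0.34 log units; beyond the scatter) in this assay, giving an estimate of 5000 nM with a range from 1500 nM to 20000 nM.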

Compound 4, half-maximal effective concentration: 4700 nM
Compound 4: the middle estimate sits 1.1-fold (0.03 log units) above what was measured; low and high end bracket the measured number.
By their numbers in this assay, from the lowest: compound 1; then compound 4; then compound 2.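

Within this assay, replacing 2-ethoxypyridin-3-yl with 2-nitrophenyl gives a 2.3-fold lower number from compound 2 to compound 4 (0.37 log units; beyond the scatter), so this position responds to the change even though the two groups have the same counts of heavy atoms and hydrogen-bond acceptors. Replacing 4-methoxyphenyl with 2-nitrophenyl gives a 2.2-fold higher number from compound 1 to compound 4 (0.35 log units; beyond the scatter), which places the new group in the middle: compound 1 still has the lowest number of the three, and compound 2 the highest. No measurement shown here explains these differences.

Within the data shown here, with only three aromatic groups compared, no rule for this position can be drawn from their order. A plain phenyl group, or an amine in place of the nitro group, would help separate the contribution of the ring from that of the group attached to it.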